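A few compounds are considered here, and "the series" means these few. Any claim that something is new, unique, unknown or untested is made for them only; others in the source may bear on it.

The compounds share one core, shown for compound 1 as `CCCCNC(=O)COc1ccc(C(=O)c2c(CCCC)oc3ccccc23)cc1`, and all were tested in a functional assay on MCF7 cells (Homo sapiens) for antiproliferative activity, read by MTT assay, with a stated time of 24 h; on this read-out lower numbers stand for stronger inhibition and higher numbers for weaker inhibition. In this assay compound 1 gives only a limit, > 50000 nM. Compound 2, `CCCCc1oc2ccccc2c1C(=O)c1ccc(OCC(=O)N2CCCC2)cc1`, carries the change (pyrrolidin-1-yl in place of butylamino on a carbonyl carbon). In this assay compound 2 gives 42400 nM. The step of an at least 1.1-fold lower number from compound 1 to compound 2 (0.07 log units; that floor lies within the scatter) shows that this change moves the read-out only a little, and the limit of > 50000 nM in this assay, at which 2 of the 3 values shown sit, marks the boundary at which the value of compound 1 sits. Compound 3, `CCCCNC(=O)CCCOc1ccc(C(=O)c2c(CCCC)oc3ccccc23)cc1`, differs from compound 1 in its core by 2-(butylcarbamoyl)ethyl in place of butylcarbamoyl on a saturated chain carbon bound to an oxygen on an aromatic ring, a longer chain. In this assay compound 3 gives only a limit, > 50000 nM. The step that the two limits leave unreadable from compound 1 to compound 3 cannot be read from two limits, and the step of an at least 1.1-fold higher number from compound 2 to compound 3 (0.07 log units; that floor lies within the scatter) is small at its floor.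

Compound 4, `CCCCc1oc2ccccc2c1C(=O)c1ccc(OCCCC(=O)N2CCCC2)cc1`, has not yet been measured. It differs from compound 3 by pyrrolidin-1-yl in place of butylamino on a carbonyl carbon, the same change, in the same surroundings, as that from compound 1 to compound 2. Because the earlier step of an at least 1.1-fold lower number from compound 1 to compound 2 (0.07 log units; that floor lies within the scatter) was small, the expected step of an at least 1.1-fold lower number from compound 3 to compound 4 (0.04 log units; that floor lies within the scatter) is also small. The estimate for compound 4 in this assay is therefore 45000 nM, with a range from 25000 nM to 90000 nM, and a real chance remains that only a limit is reported again.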

Compound 4, half-maximal inhibitory concentration: 23500 nM
For compound 4 the middle estimate is 1.9-fold (0.28 log units) above the measured one; measured number outside the range, below it.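

On the longer chain, pyrrolidin-1-yl in place of butylamino gives an at least 2.1-fold lower number from compound 3 to compound 4 (0.32 log units; beyond the scatter), and the route to the same compound from the shorter butylamino amide gives an at least 2.1-fold lower number from compound 1 to compound 4 (0.32 log units; beyond the scatter). Set side by side, the same change on the two cores reads: the same change on two cores in this assay, an at least 1.1-fold lower number (0.07 log units; that floor lies within the scatter) from compound 1 to compound 2 and an at least 2.1-fold lower number (0.32 log units; beyond the scatter) from compound 3 to compound 4; the limit leaves it open whether they differ. The lower number therefore carries over to the core of compound 3, but steps that start from a compound giving only a limit show a floor and not a true size, so nothing here says that the change is worth the same on both cores; with the pyrrolidin-1-yl amide kept in place, the longer chain gives a 1.8-fold lower number from compound 2 to compound 4 (0.26 log units; within the scatter), which does not separate the two chain lengths.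

The compounds shown leave open whether another cyclic amine on the carbonyl, such as piperidine or morpholine, or a still longer chain, would lower the number further. As far as these compounds go, the true values of compound 1 and compound 3 also stay unknown, because both rest on a single boundary: the limit of > 50000 nM in this assay, at which 2 of the 4 values shown sit.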